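This account rests on a few compounds, and the source may have more. Where it says the series, first, only, none or still open, it means among the compounds named here.

Measured compounds in a functional assay on HT-29 cells (Homo sapiens) for antiproliferative activity, read by MTT assay, with a stated time of 48 h; a higher number here means a weaker inhibitor, a lower number a stronger inhibitor:
- compound 1, `COc1cc(C(=O)/C=C/c2ccc(OCCCC(=O)NCCCCN(CCCN)CCCCN)cc2)cc(OC)c1OC`: 87200 nM
- compound 2, `COc1cc(C(=O)/C=C/c2ccc(OCCCC(=O)NCCCNCCCCN)cc2)cc(OC)c1OC`: a limit of the assay, > 100000 nM
- compound 3, `COc1ccc(/C=C/C(=O)c2cc(OC)c(OC)c(OC)c2)cc1OCCCC(=O)NCCCCN(CCCN)CCCCN`: 74700 nM

Compound 2 gives only a limit in this assay, no number. The change from compound 1 to compound 2 is (4-aminobutyl)amino in place of ((4-aminobutyl)(3-aminopropyl)amino)methyl on a saturated chain carbon, three bonds along the chain from an amide-type nitrogen and reads as an at least 1.1-fold higher number from compound 1 to compound 2 (0.05 log units; that floor lies within the scatter); it is only a floor because of the limit of > 100000 nM in this assay, at which 1 of the 3 values shown sits. Compound 3 and compound 1 share the same cadaverine-type side chain but their cores differ; that difference is not broken down here, and their two values sit within the scatter of each other.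

Compound 4, `COc1ccc(/C=C/C(=O)c2cc(OC)c(OC)c(OC)c2)cc1OCCCC(=O)NCCCNCCCCN`, is not yet measured. It differs from compound 3 by (4-aminobutyl)amino in place of ((4-aminobutyl)(3-aminopropyl)amino)methyl on a saturated chain carbon, three bonds along the chain from an amide-type nitrogen, the same change as from compound 1 to compound 2, made at the same place. The step from compound 3 to compound 4 is expected to be a 1.5-fold higher number from compound 3 to compound 4 (0.17 log units; within the scatter), resting on an at least 1.1-fold higher number from compound 1 to compound 2 (0.05 log units; that floor lies within the scatter) and on compound 3 starting from 74700 nM. Compound 4 is therefore estimated at 110000 nM, between 70000 nM and 200000 nM, with a real chance that this assay again reports only a limit.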

Compound 4, half-maximal inhibitory concentration: > 100000 nM
Compound 4: only a limit was reported; the forecaster's own chance of this, stated with the estimate: 60%; the middle value is on the limit's open side.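

In this assay compound 4 gives > 100000 nM, a limit of the assay and not a number. Carried to this second core, the change reads as an at least 1.3-fold higher number from compound 3 to compound 4 (0.12 log units; that floor lies within the scatter), and nothing here contradicts the reading on the core of compound 1: the same change on two cores in this assay, an at least 1.1-fold higher number (0.05 log units; that floor lies within the scatter) from compound 1 to compound 2 and an at least 1.3-fold higher number (0.12 log units; that floor lies within the scatter) from compound 3 to compound 4; the limit leaves it open whether they differ

The transfer is therefore consistent across the two cores, in that the product of the change ends at the limit on both, but it gives no size for the change on either core and no sign that the effect exceeds the scatter, the readings being capped by a shared ceiling: the limit of > 100000 nM in this assay, at which 2 of the 4 values shown sit.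

Compound 2 and compound 4 both give only a limit, so the two cores carrying (4-aminobutyl)amino remain uncompared. Also open, on these data alone, is how this assay responds when the side chain is cut back to a single terminal amine or ends in a carboxylic acid, and whether either group would give a number rather than a limit.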